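Swapping the aromatic ring on compound 1 for a 1,2-thiazol-5-yl group

A few compounds are considered here, and "the series" means these few. Any claim that something is new, unique, unknown or untested is made for them only; others in the source may bear on it.

In a functional assay for activation of Alpha-1B adrenergic receptor (Homo sapiens), read by calcium flux (on this read-out higher numbers stand for larger maximal responses and lower numbers for smaller maximal responses), compound 1 `c1cncc(-c2ccccc2OCC2=NCCN2)c1` gives 111%, level with compound 3 `c1ccc(-c2ccoc2)c(OCC2=NCCN2)c1` at 111%, the two together at the low end of three close numbers, with compound 2 `c1csc(-c2ccccc2OCC2=NCCN2)c1` at 112% only a touch higher. Compound 4 `c1ccc(-c2ccns2)c(OCC2=NCCN2)c1` differs from compound 1 in one place: 1,2-thiazol-5-yl in place of pyridin-3-yl on an aromatic carbon. The measured steps that exchange this same aromatic ring are a number 1 percentage points higher from compound 1 to compound 2 (within the scatter) and no change at the digits printed from compound 1 to compound 3 (within the scatter), and the pair of five-membered rings itself shows a number 1 percentage points lower from compound 2 to compound 3 (within the scatter). Because all three steps stay within the scatter, the move to a five-membered ring with two hetero atoms is expected to be no change at the digits printed from compound 1 to compound 4 (within the scatter). Compound 4 is therefore estimated at 111%, expected to fall between 100% and 122%.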

Compound 4, largest response reached (reported as maximum), in percent of the reference or control that the assay uses: 56%
Beside the measured number, compound 4's estimate is 55 percentage points above it, and the stated range ends above it.
By their numbers in this assay, from the lowest: compound 4; then compounds 1, 3 and 2 (each within the scatter of the next).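

With 1,2-thiazol-5-yl at this place, this assay gives a number 55 percentage points lower from compound 1 to compound 4 (beyond the scatter) and a number 55 percentage points lower from compound 3 to compound 4 (beyond the scatter) and a number 56 percentage points lower from compound 2 to compound 4 (beyond the scatter) as the largest drops in the series. The earlier compounds shown here suggested that the aromatic ring on this carbon could be exchanged freely, but that holds only for pyridin-3-yl, thiophen-2-yl and furan-3-yl. Being a five-membered aromatic ring is not enough to keep the response, as compound 2 and compound 3 stay high while compound 4 does not. Still open, from the compounds shown here alone, is how a plain phenyl ring, a 1,3-thiazol-5-yl ring or a methyl-bearing 1,2-thiazol-5-yl would behave here. Nothing available explains the drop.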